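Trifluoromethyl to methyl: expected cytotoxicity of compound 4

The source may report more compounds than this note shows. Statements on the series, on what has been measured and on what is new or still open speak of the compounds shown alone.

Of the compounds shown here, three sharing one core have been tested in a functional assay on HGC-27 cells (Homo sapiens) for cytotoxicity, read by MTT assay, with a stated time of 72 h; on this read-out lower numbers stand for stronger inhibition and higher numbers for weaker inhibition. Compound 1 `CCCCCCCCCCCCNc1nc(SCc2ccc(C(F)(F)F)cc2)nc2ccccc12` gives 38700 nM in this assay. Compound 2 `CCCCCCCCCCCCCCNc1nc(SCc2ccc(C(F)(F)F)cc2)nc2ccccc12` carries a longer chain, and in this assay compound 2 reaches only the limit > 50000 nM. Within the data shown here, the step of an at least 1.2-fold higher number from compound 1 to compound 2 (0.11 log units; that floor lies within the scatter) is the only one measured between compounds that differ in a single place. Compound 3 `FC(F)(F)c1ccc(CSc2nc(Nc3ccccc3C(F)(F)F)c3ccccc3n2)cc1` likewise sits at a limit in this assay, namely > 50000 nM, so only a floor for its number is known. Thus the limit of > 50000 nM in this assay, at which 2 of the 3 values shown sit, leaves compound 3 without a definite value, and no measured step touches the part of the molecule that changes next.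

Compound 4 `Cc1ccccc1Nc1nc(SCc2ccc(C(F)(F)F)cc2)nc2ccccc12` differs from compound 3 by methyl in place of trifluoromethyl on an aromatic carbon. Among the measured compounds shown here, the one measured step concerns a saturated chain, so it says nothing about this change. No step beyond the scatter can be expected in this assay, in either direction. Compound 4 is therefore expected to give about 50000 nM, with a range from 20000 nM to 120000 nM, and most likely the result will again be reported only as a limit. That estimate means an expected step of a number no higher from compound 3 to compound 4 (the limit leaves the size open), which is expected to stay within the scatter.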

Compound 4, half-maximal inhibitory concentration: 27500 nM
Beside the measured number, compound 4's estimate is 1.8-fold (0.26 log units) above it; measured number inside the range.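

In this assay, among these compounds, the exchange of trifluoromethyl for methyl, on an aromatic carbon ortho to a large group, gives an at least 1.8-fold lower number from compound 3 to compound 4 (0.25 log units; that floor lies within the scatter), and this is the first step that can be read at this position of the molecule. With methyl at this place, the compound yields a definite number rather than a limit, so a ring-bearing amine on the shared core can be placed on the scale of this read-out, although the step as read so far cannot be called a real gain in strength. On these data alone, how large the step truly is remains unknown because one of its two ends is only a limit, a situation that also applies to another compound: the limit of > 50000 nM in this assay, at which 2 of the 4 values shown sit.

The compounds shown leave open what other small groups at the same place, such as chlorine, methoxy or a plain hydrogen, would give in this assay. They also leave open whether a larger number of groups on this ring, for instance an amine or a carboxylic acid, would move the number beyond the usual scatter.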